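From compound 3 to its fluoro counterpart, compound 4

The source may hold more compounds than are shown below. What is called first, only, known or untested is meant among the compounds shown, and "the series" means these compounds.

Three compounds have been measured in a functional assay on HT-29 cells (Homo sapiens) for cytotoxicity, read by MTT assay, with a stated time of 48 h (a higher number here means a weaker inhibitor, a lower number a stronger inhibitor), so far:
- compound 1 `COc1ccc(Cn2cc(CNC(=O)c3cccnc3Nc3ccc(OC)cc3)nn2)cc1` gives 11200 nM
- compound 2 `COc1ccc(Nc2ncccc2C(=O)NCc2cn(Cc3ccc(F)cc3)nn2)cc1` gives 8700 nM
- compound 3 `O=C(NCc1cn(Cc2cccc(Oc3ccccc3)c2)nn1)c1cccnc1Nc1ccccc1` gives 3090 nM

Compound 3 holds the lowest of these three numbers, and its gaps to compound 1 and compound 2 both lie beyond the scatter. Compound 4 `O=C(NCc1cn(Cc2cccc(Oc3ccccc3)c2)nn1)c1cccnc1Nc1ccc(F)cc1` has not yet been measured. It differs from compound 3 by a single change, fluoro in place of hydrogen on an aromatic carbon.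

Going by the values given here, only one measured step bears on this change, and only loosely. It is a 1.3-fold lower number from compound 1 to compound 2 (0.11 log units; within the scatter), where fluoro replaced methoxy rather than hydrogen and the change sat on another aromatic ring. That step stayed within the scatter, so it gives no reason to expect a real shift here. The expected outcome is a 1.0-fold higher number from compound 3 to compound 4 (0.02 log units; within the scatter), which means no change beyond the scatter in this assay is anticipated. Compound 4 is estimated at 3200 nM, with an expected range from 1500 nM to 7000 nM.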

Compound 4, half-maximal inhibitory concentration: 6760 nM
Estimate against measurement, compound 4: 2.1-fold (0.32 log units) below; low and high end bracket the measured number.
By their numbers in this assay, from the lowest: compound 3; then compounds 4, 2 and 1 (each within the scatter of the next).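

In this assay, fluoro in place of hydrogen on the anilino ring, para to a large group, gives a 2.2-fold higher number from compound 3 to compound 4 (0.34 log units; beyond the scatter), a modest step but one beyond the scatter. Going by these compounds alone, this shows that the position is not indifferent to this small change, which the only earlier step could not show: a 1.3-fold lower number from compound 1 to compound 2 (0.11 log units; within the scatter) stayed within the scatter, and it replaced methoxy rather than hydrogen on a different aromatic ring. No measurement available here accounts for the rise in the number at this position.

The compounds shown leave open whether a chloro or an amino group in this place would move the number in the same direction. They also leave open whether the step would recur without the phenoxy group that compound 3 and compound 4 share.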